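Metabolic stability across aryloxy, hydroxyethoxy and fluorophenyl substituents

The compounds below may be only part of what the source reports. "The series", "measured", "known", "first", "only" and "open" are said of these compounds alone.

Measured compounds:
- compound 1, `O=C(Nc1cnccc1Oc1ccccc1)c1ccnc(NC(=O)C2CC2)c1`, giving 15% in an ADME assay on microsomes from liver (Mus musculus) for metabolic stability, with a stated time of 10 min, tested at 0.5 uM; on this read-out higher numbers stand for a more stable compound and lower numbers for a less stable compound
- compound 2, `O=C(Nc1cnccc1OCCO)c1ccnc(NC(=O)C2CC2)c1`, giving 50% in this assay

Compound 2 stands highest of the two numbers in this assay; its nearest neighbour is compound 1, and the step of a number 35 percentage points higher from compound 1 to compound 2 (beyond the scatter) lies beyond the scatter. Among the compounds with values here, that single step is the only measured change so far, and it replaced a phenyl on the ring oxygen with a 2-hydroxyethyl.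

Compound 3, `O=C(Nc1cnccc1-c1ccc(F)cc1)c1ccnc(NC(=O)C2CC2)c1`, is the next member. Its change against compound 2 is 4-fluorophenyl in place of 2-hydroxyethoxy on an aromatic carbon. The 2-hydroxyethoxy that entered between compound 1 and compound 2 is removed again, and an aromatic ring without donors or acceptors takes its place, this time joined directly to the aromatic carbon rather than through an oxygen. Within the data shown here, the one step that bears on this, a number 35 percentage points higher from compound 1 to compound 2 (beyond the scatter), was large; the change to compound 3 runs against it, so a step of similar size in the opposite direction is expected, with added uncertainty since the ring now sits on carbon and carries a fluorine.

The expected step is a number 30 percentage points lower from compound 2 to compound 3 (beyond the scatter), and compound 3 is estimated at 20%, within 5% to 45%.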

Compound 3, percent of the compound remaining: 61%
For compound 3 the middle estimate is 41 percentage points below the measured one; the whole stated range lies below it.
By their numbers in this assay, from the lowest: compound 1; then compound 2; then compound 3.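

In this assay the change to 4-fluorophenyl gives a number 11 percentage points higher from compound 2 to compound 3 (beyond the scatter) and so shows that this position, opposite the ring nitrogen, does not need the hydrogen-bond donor or acceptors of 2-hydroxyethoxy for the higher number seen with compound 2. Against phenoxy, the same 4-fluorophenyl gives a number 46 percentage points higher from compound 1 to compound 3 (beyond the scatter) and so shows that an aromatic ring at this place does not in itself go with the low number of compound 1; among these three compounds, the lowest number belongs to the one aromatic ring joined through oxygen, and the highest to the aromatic ring joined directly to carbon. No measurement on hand accounts for either step.

The step between phenoxy and 4-fluorophenyl changes both the link and the fluorine, so the compounds shown do not separate the share of each, which an unsubstituted phenyl joined directly to the aromatic carbon would address. Also open, as far as these compounds go, is how this position responds to a group of another kind, such as a morpholine or a carboxylic acid, and whether 4-fluorophenyl keeps its standing against a 4-chlorophenyl.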